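The source may report more compounds than this note shows. Statements on the series, on what has been measured and on what is new or still open speak of the compounds shown alone.

Measured so far in a functional assay (strain AB) with Danio rerio as the target, read by microscopy, with a stated time of 1 h; a lower number here means that less compound is needed, a higher number that more compound is needed for the effect:
- Compound 1 `CCN1CCc2c(sc(NC(=O)Nc3ccc(Cl)cc3)c2C(=O)OC)C1`: > 25000 nM, a limit of the assay.
- Compound 2 `CCN1CCc2c(sc(NC(=O)Nc3ccc(Cl)cc3)c2C(=O)c2nnco2)C1`: > 25000 nM, a limit of the assay.

Within the data shown here, compound 2 therefore has no numerical value, and the only other measured compound offers none either. Both sit at the limit of > 25000 nM in this assay, at which 2 of the 2 values shown sit. Compound 3 `CCN1CCc2c(sc(NC(=O)Nc3ccc(Cl)cc3)c2C(=O)N2CCOCC2)C1` has morpholin-4-yl in place of 1,3,4-oxadiazol-2-yl on a carbonyl carbon.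

Among the measured compounds shown here, the one measured step at this carbonyl carbon is a step that the two limits leave unreadable from compound 1 to compound 2, so it gives neither a size nor a direction for the new change. For the measured compounds named here, with no measured step to suggest otherwise, no change beyond the scatter is expected in this assay, and another limit is the likeliest outcome. The estimated step is a number no higher from compound 2 to compound 3 (the limit leaves the size open). For compound 3 the expected value is 25000 nM, with an estimated range of 8000 nM to 40000 nM.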

Compound 3, half-maximal effective concentration: > 25000 nM
Compound 3: only a limit was reported (the forecaster's own chance of this, stated with the estimate: 75%); the middle value lies on the limit itself.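

No step can be read among compound 1, compound 2 and compound 3, as each result is a limit and not a number: the limit of > 25000 nM in this assay, at which 3 of the 3 values shown sit.

The compounds shown leave open whether any group on the carbonyl carbon can bring a measurable effect in this assay within the shared core.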